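The compounds below may be only part of what the source reports. "The series", "measured", "known", "first", "only" and "open" are said of these compounds alone.

Compound 1 `Cn1c(-c2ccccc2)cnc1NC(=O)c1ccccc1`. In a toxicity assay on THP-1 cells (Homo sapiens) for inhibition (on this read-out lower numbers stand for higher toxicity in this test and higher numbers for lower toxicity in this test), compound 1 gives > 100000 nM, a limit of the test rather than a number.
Compound 2 `COc1ccc(-c2cnc(NC(=O)c3cccc([N+](=O)[O-])c3)n2C)cc1`. In this assay compound 2 gives > 100000 nM, again a limit rather than a number.
Compound 3 `COc1ccc(-c2cnc(NC(=O)c3ccccc3)n2C)cc1`. In this assay compound 3 gives > 100000 nM, also a limit rather than a number.

Compound 3 therefore stands where every measured compound stands: all three values sit at the limit of > 100000 nM in this assay, at which 3 of the 3 values shown sit. The two steps that lead to compound 3, a step that the two limits leave unreadable from compound 1 to compound 3 and a step that the two limits leave unreadable from compound 2 to compound 3, are unreadable for the same reason, so no measured change in this series has shown a readable size.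

Compound 4 `COc1ccc(-c2cnc(NC(=O)c3ccccc3Cl)n2C)cc1` differs from compound 3 by chloro in place of hydrogen on an aromatic carbon. Within the data shown here, no measured step touches this part of the molecule, so the only guide is that every compound so far has reached the limit. The step from compound 3 to compound 4 is therefore expected to be small, roughly a number no higher from compound 3 to compound 4 (the limit leaves the size open), with no direction favoured. For compound 4 the expected value in this assay is 100000 nM, between 40000 nM and 250000 nM, most likely reported again only as a limit.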

Compound 4, half-maximal cytotoxic concentration: > 50000 nM
Compound 4: no number, only a limit; the forecaster's own chance of this, stated with the estimate: 80%; the middle value is on the limit's open side.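

Compound 3 and compound 4 are both reported only as limits, so the size of the change from hydrogen to chloro between them cannot be read. The compounds shown leave open whether this assay would give an actual number for any of them, and so which change, if any, alters toxicity.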